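The source may report more compounds than this note shows. Statements on the series, on what has been measured and on what is new or still open speak of the compounds shown alone.

Measured compounds, antagonist potency in a functional assay on CHO-K1 cells for antagonist activity at growth hormone secretagogue receptor type 1 (Homo sapiens), read by luminescence and calcium flux; a higher number here means a weaker inhibitor, a lower number a stronger inhibitor:
Compound 1 `C[C@H]1CN(C(=O)c2ccc(-c3ccncc3F)c(F)c2)CCN1C(=O)c1ccc2cc[nH]c2c1` gives 42 nM.
Compound 2 `Cc1noc(C)c1-c1ccc(C(=O)N2CCN(C(=O)c3ccc4cc[nH]c4c3)[C@@H](C)C2)cc1` gives 245 nM.

Compound 2 stands at the higher of the two numbers, compound 1 sitting at a lower value in this assay by a margin beyond the scatter. Compound 3 `C[C@H]1CN(C(=O)c2ccc(-c3ccncc3F)cc2)CCN1C(=O)c1ccc2cc[nH]c2c1` is not yet measured; it arises from compound 2 by 3-fluoropyridin-4-yl in place of 3,5-dimethyl-1,2-oxazol-4-yl on an aromatic carbon. The same 3-fluoropyridin-4-yl group is carried by compound 1, whose value in this assay is the lower of the two shown, so a step down in this assay is expected, of size a 4.1-fold lower number from compound 2 to compound 3 (0.61 log units; beyond the scatter). For compound 3 the estimate is 60 nM, within 25 nM to 150 nM.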

Compound 3, half-maximal inhibitory concentration: 31 nM
Compound 3: the middle estimate sits 1.9-fold (0.29 log units) above what was measured; the range from low to high includes it.
By their numbers in this assay, from the lowest: compounds 3 and 1 (each within the scatter of the next); then compound 2.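

In this assay, 3-fluoropyridin-4-yl in place of 3,5-dimethyl-1,2-oxazol-4-yl gives a 7.9-fold lower number from compound 2 to compound 3 (0.90 log units; beyond the scatter) as a single change, so the group on this aromatic carbon, para to a large group, matters to the series. With hydrogen in place of fluoro, a 1.4-fold lower number from compound 1 to compound 3 (0.13 log units; within the scatter) leaves the two compounds indistinguishable in this assay, so the fluoro of compound 1 is not needed for this level of potency. No supporting data explain the step between the two aryl groups.

Still open, going by these compounds, is whether the nitrogen or the fluorine of 3-fluoropyridin-4-yl carries the step. Also open, on these data alone, is how a plain phenyl, or a pyridine bearing an amine, would read at this position.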